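A few compounds are considered here, and "the series" means these few. Any claim that something is new, unique, unknown or untested is made for them only; others in the source may bear on it.

Measured so far in a functional assay on PANC-1 cells (Homo sapiens) for inhibition, read by MTT assay, with a stated time of 24 h, tested at 10 uM; a lower number here means less inhibition, a higher number more inhibition at the concentration tested (going by the name of the read-out):
compound 1 `CC(C)=CCC/C(C)=C/CC1Cc2c(O)cc(=O)n(CCCO)c2CC1(C)C`: 28.7%
compound 2 `CC(C)=CCOc1cc(=O)n(CCCO)c2c1CC(CC=C(C)C)C(C)(C)C2`: 20.7%
compound 3 `CC(C)=CCC1Cc2c(OCCCNS(=O)(=O)c3ccc([N+](=O)[O-])cc3)cc(=O)n(CCCO)c2CC1(C)C`: 47.7%

Compound 2 has the lowest of the three numbers. Compound 1 sits within the scatter of it, so no order between these two is drawn; compound 3 lies beyond the scatter above compound 2. Among the measured compounds shown here, no pair differing in a single place has been measured, so no step size is known from the series itself.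

Compound 4 `CC(C)=CCC1Cc2c(OC(=O)Nc3ccc(F)c(Cl)c3)cc(=O)n(CCCO)c2CC1(C)C` arises from compound 2 by (3-chloro-4-fluorophenyl)carbamoyl in place of 3-methylbut-2-en-1-yl on an oxygen on an aromatic ring. The only point of reference is compound 3, where a different group on the oxygen on the aromatic ring went with the higher value 47.7%; one compound is not a pattern. For compound 4 a modest rise in this assay is expected, a number 17.3 percentage points higher from compound 2 to compound 4 (beyond the scatter), with wide uncertainty. Compound 4 is estimated at 38%, range 24% to 56%.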

Compound 4, a percentage reported as inhibition, at one concentration (the size of the read-out at that concentration, not a potency): 79.8%
Estimate against measurement, compound 4: 41.8 percentage points below; the whole stated range lies below it.
By their numbers in this assay, from the lowest: compounds 2 and 1 (each within the scatter of the next); then compound 3; then compound 4.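

In this assay, a number 59.1 percentage points higher from compound 2 to compound 4 (beyond the scatter) comes from replacing 3-methylbut-2-en-1-yl with (3-chloro-4-fluorophenyl)carbamoyl on the oxygen on an aromatic ring. Among the compounds shown here, this is the first single-place step, and it shows that the group on this oxygen alone can shift the read-out by a large amount. Nothing measured here accounts for the size of the step.

On these data alone, whether the rise belongs to the carbamoyl link or to the halogenated phenyl ring remains open. An unsubstituted phenylcarbamoyl or a plain acetyl group on this oxygen would separate the two.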